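A few compounds are considered here, and "the series" means these few. Any claim that something is new, unique, unknown or untested is made for them only; others in the source may bear on it.

Compound 1 (`Oc1cccc(C(c2c[nH]c3ccc(Br)cc23)c2c[nH]c3ccc(Br)cc23)c1`), compound 2 (`COc1cccc(C(c2c[nH]c3ccc(Br)cc23)c2c[nH]c3ccc(Br)cc23)c1OC`) and compound 3 (`Brc1ccc2[nH]cc(C(c3c[nH]c4ccc(Br)cc34)C3CCCCC3)c2c1`) have the same shared core and differ in the group on a saturated chain carbon bound to two aromatic carbons. In a functional assay on A549 cells (Homo sapiens) for inhibition, read by MTT assay, with a stated time of 48 h (on this read-out lower numbers stand for stronger inhibition and higher numbers for weaker inhibition), compound 1 gives 8000 nM, compound 3 gives 5500 nM and compound 2 gives 100000 nM. Compound 2 therefore has the highest number of the three, making it the weakest inhibitor in this small set.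

The next compound is compound 4 (`Brc1ccc(C(c2c[nH]c3ccc(Br)cc23)c2c[nH]c3ccc(Br)cc23)cc1`), which carries 4-bromophenyl in place of 2,3-dimethoxyphenyl at that carbon: 4-bromophenyl in place of 2,3-dimethoxyphenyl on a saturated chain carbon bound to two aromatic carbons.

Among the compounds with values here, no measured compound carries the 4-bromophenyl group, so the evidence is indirect. Two measured steps replace the 2,3-dimethoxyphenyl group's position with something else, and both are large: a 13-fold higher number from compound 1 to compound 2 (1.10 log units; beyond the scatter), and an 18-fold lower number from compound 2 to compound 3 (1.26 log units; beyond the scatter). The third step, a 1.5-fold lower number from compound 1 to compound 3 (0.16 log units; within the scatter), shows that two quite different groups can give similar values. Among these three compounds, only compound 2 stands apart. On that basis, a large drop is expected in this assay, with the expected change being a 10-fold lower number from compound 2 to compound 4 (1.00 log units; beyond the scatter). The uncertainty is wide, since a single unusual compound sets this pattern.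

For compound 4, the estimated value is 10000 nM, with an expected range of 3000 nM to 40000 nM.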

Compound 4, half-maximal inhibitory concentration: 5600 nM
Estimate against measurement, compound 4: 1.8-fold (0.25 log units) above; low and high end bracket the measured number.
By their numbers in this assay, from the lowest: compounds 3, 4 and 1 (each within the scatter of the next); then compound 2.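

In this assay, replacing the 2,3-dimethoxyphenyl group with 4-bromophenyl on the saturated chain carbon gives a large step, an 18-fold lower number from compound 2 to compound 4 (1.25 log units; beyond the scatter), while the two other new comparisons stay within the scatter: a 1.0-fold higher number from compound 3 to compound 4 (0.01 log units; within the scatter) and a 1.4-fold lower number from compound 1 to compound 4 (0.15 log units; within the scatter). With three compounds, the earlier data rested on one pair of close values, but now three different groups (3-hydroxyphenyl, cyclohexyl and 4-bromophenyl) give values that cannot be told apart, and compound 2 alone stands apart as the weakest of the four. This position therefore tolerates quite different groups among those shown, with the 2,3-dimethoxyphenyl group as the one exception, and nothing measured here explains that exception.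

The compounds shown do not reveal whether both methoxy groups are needed for the high number of compound 2, or whether a phenyl ring carrying a single methoxy group would give the same result. They also leave open whether an amine, a carboxylic acid or a longer chain at this carbon would stay with compounds 1, 3 and 4 or would stand apart.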